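Methoxy to phenoxy on two pendant rings, one core

The compounds below may be only part of what the source reports. "The series", "measured", "known", "first", "only" and "open" are said of these compounds alone.

Compound 1 `CCCn1ccc2cc(-c3ccc(OC)nc3)cc(Cl)c2c1=O` and compound 3 `CCCn1ccc2cc(-c3ccc(OC)cc3)cc(Cl)c2c1=O` share the same core and differ in the pendant ring that carries the methoxy group; the difference between those two parts is not broken down here. Among the compounds with values here, in a functional assay on CHO cells for agonist activity at metabotropic glutamate receptor 2 (Homo sapiens), read by GTPgammaS binding (on this read-out lower numbers stand for smaller maximal responses and higher numbers for larger maximal responses), compound 1 gives 121%, and compound 3 gives 136%, the highest of the three numbers measured so far, with both of its steps to the other two beyond the scatter.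

Compound 2 `CCCn1ccc2cc(-c3ccc(Oc4ccccc4)nc3)cc(Cl)c2c1=O` is compound 1 with phenyl in place of methyl on an oxygen on an aromatic ring. In this assay compound 2 gives 92%, so the change produced a number 29 percentage points lower from compound 1 to compound 2 (beyond the scatter).

Compound 4 `CCCn1ccc2cc(-c3ccc(Oc4ccccc4)cc3)cc(Cl)c2c1=O` applies the same change to compound 3: phenyl in place of methyl on an oxygen on an aromatic ring. The place is described in the same words in both cases, an oxygen on an aromatic ring whose other neighbour is an aromatic carbon, so the two changes are the same change made on two different pendant rings. Within the data shown here, only one earlier step of this kind exists, and it sits on the other pendant ring, so carrying it over is an assumption rather than a pattern.

Among the measured compounds shown here, on that basis compound 4 is expected to show a number 29 percentage points lower from compound 3 to compound 4 (beyond the scatter), set beside the earlier a number 29 percentage points lower from compound 1 to compound 2 (beyond the scatter), because a number 29 percentage points lower from compound 1 to compound 2 (beyond the scatter) is the only comparable step available. In this assay compound 4 is estimated at 107%, with the expected range running from 90% to 125%.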

Compound 4, largest response reached (Emax), in percent of the reference or control that the assay uses: 88%
The estimate for compound 4 lay 19 percentage points above the measured number; measured number below the stated range.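

Phenyl in place of methyl on an oxygen on an aromatic ring gives a lower maximal response on both pendant rings in this assay, and on the second ring the step is a number 48 percentage points lower from compound 3 to compound 4 (beyond the scatter). The direction of the change therefore carries from one core to the other in these two pairs, but its size does not, and a step taken from one core is a poor guide to the exact size on the other: the same change on two cores in this assay, a number 29 percentage points lower (beyond the scatter) from compound 1 to compound 2 and a number 48 percentage points lower (beyond the scatter) from compound 3 to compound 4, 19 percentage points apart, beyond the scatter of two such steps. These two pairs show neither what produces the gap between the steps nor that the same direction would hold on any further core, and with one step per core, no typical size can be given for either.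

The compounds shown leave open how the response would move with other groups on that oxygen, such as ethyl or benzyl, or with an amine in place of the oxygen. They also leave open whether a step on a third pendant ring would lie nearer the smaller step, nearer the larger one, or outside both.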